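From pyridin-3-yl to pyridin-4-yl in the series

A few compounds are considered here, and "the series" means these few. Any claim that something is new, unique, unknown or untested is made for them only; others in the source may bear on it.

In a functional assay on QGY-7703 cells (Homo sapiens) for cytotoxicity, read by MTT assay, with a stated time of 24 h (on this read-out lower numbers stand for stronger inhibition and higher numbers for weaker inhibition), compound 1 (`COc1ccc(/C=C2\CN(C)C/C(=C\c3cccnc3)C2=O)c(OC)c1OC`) gives 2630 nM and compound 2 (`CN1C/C(=C\c2cccnc2)C(=O)/C(=C/c2ccc(F)cc2Br)C1`) gives 2610 nM, two values within the scatter of each other. Compound 3 (`COc1ccc(/C=C2\CN(C)C/C(=C\c3ccncc3)C2=O)c(OC)c1OC`) awaits measurement and carries pyridin-4-yl in place of pyridin-3-yl on a double-bonded chain carbon bound to a double-bonded ring carbon. Among the compounds with values here, no measured pair isolates this change, so no step beyond the scatter is expected in this assay, in either direction. The expected change is small, a 1.2-fold lower number from compound 1 to compound 3 (0.08 log units; within the scatter). The estimate for compound 3 is 2200 nM, with an expected range of 900 nM to 5200 nM.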

Compound 3, half-maximal inhibitory concentration: 8350 nM
Beside the measured number, compound 3's estimate is 3.8-fold (0.58 log units) below it; measured number outside the range, above it.
By their numbers in this assay, from the lowest: compounds 2 and 1 (each within the scatter of the next); then compound 3.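

In this assay, pyridin-4-yl in place of pyridin-3-yl on a double-bonded chain carbon bound to a double-bonded ring carbon gives a 3.2-fold higher number from compound 1 to compound 3 (0.50 log units; beyond the scatter). This position therefore responds to which pyridine isomer it carries, although the two groups have the same atom and acceptor counts. Nothing available accounts for the step.

Still open, going by these compounds, is whether pyridin-2-yl or a plain phenyl at this place would fall with compound 1 or with compound 3. The same exchange on the core of compound 2 also remains to be read.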